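Methoxy on the Benzoyl Ring: Compound 3 to Compound 4

The compounds below may be only part of what the source reports. "The series", "measured", "known", "first", "only" and "open" are said of these compounds alone.

Compound 1, `COc1ccc(C(=O)/C=C/c2cc(-c3cc(OC)c(OC)c(OC)c3)n3nc(-c4ccccc4)cc3n2)cc1OC`, gives 17800 nM in a functional assay on A549 cells (Homo sapiens) for antiproliferative activity, read by MTT assay, with a stated time of 24 h; a higher number here means a weaker inhibitor, a lower number a stronger inhibitor.
Compound 2, `COc1cc(-c2cc(/C=C/C(=O)c3ccc(C)c(C)c3)nc3cc(-c4ccccc4)nn23)cc(OC)c1OC`, gives 10600 nM in this assay.
Compound 3, `COc1cc(-c2cc(/C=C/C(=O)c3ccccc3)nc3cc(-c4ccccc4)nn23)cc(OC)c1OC`, gives 18200 nM in this assay.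

Compound 3 sits alongside the other two in this assay: a 1.0-fold higher number from compound 1 to compound 3 (0.01 log units; within the scatter), and a 1.7-fold higher number from compound 2 to compound 3 (0.23 log units; within the scatter), so none of the three is set apart. Compound 4, `COc1ccc(C(=O)/C=C/c2cc(-c3cc(OC)c(OC)c(OC)c3)n3nc(-c4ccccc4)cc3n2)cc1`, differs from compound 3 by methoxy in place of hydrogen on an aromatic carbon. Among the compounds with values here, the steps that bear on this both alter the ring on the carbonyl carbon, and both fell within the scatter, so adding a methoxy there is expected to leave the number much where it is: a 1.1-fold lower number from compound 3 to compound 4 (0.03 log units; within the scatter) is the step expected. Compound 4 is therefore estimated at 17000 nM, with a range from 8000 nM to 36000 nM.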

Compound 4, half-maximal inhibitory concentration: 14600 nM
Beside the measured number, compound 4's estimate is 1.2-fold (0.07 log units) above it; low and high end bracket the measured number.
By their numbers in this assay, from the lowest: compounds 2, 4, 1 and 3 (each within the scatter of the next).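

Compound 4 adds a single methoxy to the benzoyl ring of compound 3, and in this assay this stays within the scatter (a 1.2-fold lower number from compound 3 to compound 4 (0.10 log units; within the scatter)). The 4-methoxyphenyl ring also reads the same as the 3,4-dimethoxyphenyl ring (a 1.2-fold lower number from compound 1 to compound 4 (0.09 log units; within the scatter)) and the 3,4-dimethylphenyl ring (a 1.4-fold higher number from compound 2 to compound 4 (0.14 log units; within the scatter)), so no ring on the carbonyl carbon among these four compounds sets one apart. No measurement here offers a reason for this flat result.

Going by these compounds, whether an amine or a carboxylic acid on this ring would move the number beyond the scatter remains open.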